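The source may report more compounds than this note shows. Statements on the series, on what has been measured and on what is new or still open speak of the compounds shown alone.

Of the compounds shown here, three built on a shared core have been tested in a functional assay on CCRF-CEM cells for antagonist activity at C-X-C chemokine receptor type 4 (Homo sapiens), read by calcium flux, with stated times of 25 min and 90 s; a lower number here means a stronger inhibitor, a higher number a weaker inhibitor. Compound 1 `c1cnc2c(c1)CCC[C@@H]2N(CC1CC1)C[C@H]1Cc2c(cccc2N2CCNCC2)CN1` gives 26.7 nM in this assay. Compound 2 `C[C@@H]1CN(c2cccc3c2C[C@H](CN(C)[C@H]2CCCc4cccnc42)NC3)C[C@H](C)N1C` gives 14.1 nM in this assay, and compound 3 `CN(C[C@H]1Cc2c(cccc2N2CCN(c3ccccn3)CC2)CN1)[C@H]1CCCc2cccnc21` gives 17.9 nM. Compound 1 therefore has the highest of the three numbers, yet its gaps to compound 3 and to compound 2 both lie within the scatter of repeated measurements, so none of the three can be called the stronger or the weaker inhibitor.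

Compound 4 `CCN(C[C@H]1Cc2c(cccc2N2CCNCC2)CN1)[C@H]1CCCc2cccnc21` has not yet been measured. It differs from compound 1 in one place: methyl in place of cyclopropyl on a saturated chain carbon bound to an amine nitrogen. Among the compounds with values here, no measured pair in this set isolates that change. Compound 2 and compound 3 both lack the cyclopropyl and their numbers sit close to that of compound 1, which hints that this part of the molecule does not move the read-out much, although both also differ from compound 1 elsewhere. In this assay a step of no size beyond the scatter is expected, in either direction. For compound 4 the estimated value in this assay is 22 nM, within a range from 9 nM to 55 nM. The expected step is a 1.2-fold lower number from compound 1 to compound 4 (0.08 log units; within the scatter).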

Compound 4, half-maximal inhibitory concentration: 14.8 nM
Estimate against measurement, compound 4: 1.5-fold (0.17 log units) above; measured number inside the range.
By their numbers in this assay, from the lowest: compounds 2, 4, 3 and 1 (each within the scatter of the next).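

Replacing cyclopropyl with methyl, which turns cyclopropylmethyl into ethyl on the amine nitrogen, gives a clean comparison in which only this one place differs: in this assay the pair shows a 1.8-fold lower number from compound 1 to compound 4 (0.26 log units; within the scatter). Within the data shown here, the cyclopropyl ring can therefore be removed from this position without a shift that can be told apart from ordinary repeat-to-repeat variation, something the earlier compounds could only hint at, as each of them differs from compound 1 in more than one place. No measurement shown explains why the two compounds read alike.

The compounds shown leave open whether this position accepts a group of a different kind or much greater size, such as a benzyl group, a carboxylic acid or a longer chain ending in an amine. On these data alone, the swap is also seen on only one background, so it remains unknown whether it would read the same alongside the other groups that compound 2 and compound 3 carry.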